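The source may report more compounds than this note shows. Statements on the series, on what has been measured and on what is new or still open speak of the compounds shown alone.

Measured so far:
Compound 1 `CCOC(=O)C1CCN(C(=O)CN2CN(c3ccccc3)C3(CCN(C(=O)c4ccc(C5CCCCC5)cc4)CC3)C2=O)CC1`: in an assay on HEK293 cells for displacement of a labelled ligand from NPC1-like intracellular cholesterol transporter 1 (Homo sapiens) (on this read-out lower numbers stand for stronger inhibition and higher numbers for weaker inhibition), compound 1 gives 900 nM.
Compound 2 `CC(C)(C)c1ccc(C(=O)N2CCC3(CC2)C(=O)N(CC(=O)NCN)CN3c2ccccc2)cc1`: compound 2 gives 26500 nM.
Compound 3 `CC(C)(C)OC(=O)NC1CCCN(C(=O)CN2CN(c3ccccc3)C3(CCN(C(=O)c4ccc(C(C)(C)C)cc4)CC3)C2=O)C1`: compound 3 gives 4200 nM.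

Among these three numbers, compound 3 holds the second highest: its value sits well above that of compound 1 and well below that of compound 2, both gaps beyond the usual scatter. Compound 4 `CC1CCCN(C(=O)CN2CN(c3ccccc3)C3(CCN(C(=O)c4ccc(C(C)(C)C)cc4)CC3)C2=O)C1` differs from compound 3 in one place: methyl in place of (tert-butoxycarbonyl)amino on a saturated ring carbon. Among the measured compounds shown here, no pair of measured compounds differs in just this way, so the size of this step is unknown. The expectation is a modest shift in this assay, not clearly beyond the scatter, in either direction. Compound 4 is therefore expected to give about 3000 nM, most likely between 700 nM and 13000 nM, which means an estimated step of a 1.4-fold lower number from compound 3 to compound 4 (0.15 log units; within the scatter).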

Compound 4, half-maximal inhibitory concentration: 12000 nM
The estimate for compound 4 lay 4.0-fold (0.60 log units) below the measured number; the range from low to high includes it.
By their numbers in this assay, from the lowest: compound 1; then compound 3; then compound 4; then compound 2.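

In this assay, the group on the saturated ring carbon matters: replacing (tert-butoxycarbonyl)amino with methyl weakens inhibition (a 2.9-fold higher number from compound 3 to compound 4 (0.46 log units; beyond the scatter)). On the carbonyl carbon, 3-methylpiperidin-1-yl in place of (aminomethyl)amino moves the number the other way (a 2.2-fold lower number from compound 2 to compound 4 (0.34 log units; beyond the scatter)). Nothing available explains either step.

As far as these compounds go, it remains open whether the loss in compound 4 follows from the smaller group or from losing the hydrogen-bond donor and acceptors. A plain amino group or an ethyl chain on that ring carbon could help separate the two.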